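The source may report more compounds than this note shows. Statements on the series, on what has been measured and on what is new or still open speak of the compounds shown alone.

Compound 1 `CC1=CC[C@H](C(C)(C)NC(=S)N/N=C/c2ccccc2)CC1`: in an ADME assay on Vero cells (Chlorocebus sabaeus) for inhibition, read by sulforhodamine B assay, with a stated time of 48 h (on this read-out lower numbers stand for stronger inhibition of growth and higher numbers for weaker inhibition of growth), compound 1 gives > 100000 nM, a limit of the assay.
Compound 2 `CC1=CC[C@H](C(C)(C)NC(=S)N/N=C/c2ccc(O)cc2)CC1`: in this assay compound 2 gives > 100000 nM, likewise a limit.
Compound 3 `CC1=CC[C@H](C(C)(C)NC(=S)N/N=C/c2ccccc2Cl)CC1`: in this assay compound 3 gives > 100000 nM, again a limit.

Compound 3 therefore stands at the same limit as the two other measured compounds, and the numbers do not separate any of the three. The step to compound 4 `CC1=CC[C@H](C(C)(C)NC(=S)N/N=C/c2ccc(Cl)cc2)CC1` is 4-chlorophenyl in place of 2-chlorophenyl on a carbon with a double bond to nitrogen. Going by the values given here, three measured steps touch this series: a step that the two limits leave unreadable from compound 1 to compound 2, a step that the two limits leave unreadable from compound 1 to compound 3 and a step that the two limits leave unreadable from compound 2 to compound 3, none of which can be read as to size, since each runs from one limit to another. The evidence gathered here is the limit of > 100000 nM in this assay, at which 3 of the 3 values shown sit, which tells the reader only that every aryl variation tried so far has left growth inhibition at the limit. Nothing in these data points to a direction for the step to compound 4, so the expected step that the limit leaves unreadable from compound 3 to compound 4 is none beyond the scatter. Compound 4 is therefore estimated at 150000 nM, with a range from 50000 nM to 500000 nM, most likely reported as a limit once more.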

Compound 4, concentration for total growth inhibition: > 100000 nM
Compound 4 ended at the assay's limit (the forecaster's own chance of this, stated with the estimate: 85%); the middle value does not contradict the limit.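

In this assay compound 4 gives > 100000 nM, a limit of the assay. Its steps from compound 1, compound 2 and compound 3 therefore cannot be read as to size. The compounds shown leave open whether any change to the aryl group on the shared core would bring growth inhibition into a measurable range: the limit of > 100000 nM in this assay, at which 4 of the 4 values shown sit.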